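Compound 2 to Compound 4: Propylcarbamoyl in Place of Isopropylcarbonyl

This account rests on a few compounds, and the source may have more. Where it says the series, first, only, none or still open, it means among the compounds named here.

Measured compounds:
- compound 1, `CC(C)C(=O)Nc1ccc(S(=O)(=O)Oc2ccccc2C(C)C)cc1`, 14000 nM
- compound 2, `CC(C)C(=O)Nc1ccc(S(=O)(=O)Oc2ccccc2I)cc1`, 13000 nM
- compound 3, `CC(C)c1ccccc1OS(=O)(=O)c1ccc(NC(=O)C(C)(C)C)cc1`, 15000 nM

Of the compounds shown here, three sharing one core have been tested in a functional assay on HT-29 cells (Homo sapiens) for antiproliferative activity, read by sulforhodamine B assay, with a stated time of 48 h; a lower number here means a stronger inhibitor, a higher number a weaker inhibitor. Compound 1 gives 14000 nM. Compound 2, which carries iodo in place of isopropyl on an aromatic carbon, gives 13000 nM, and the step of a 1.1-fold lower number from compound 1 to compound 2 (0.03 log units; within the scatter). Compound 3, with methyl in place of hydrogen on the saturated chain carbon bound to the carbonyl, gives 15000 nM, the step of a 1.1-fold higher number from compound 1 to compound 3 (0.03 log units; within the scatter). Compound 2 thus holds the lowest number of the three, but all three values sit within the scatter of one another, so no order among them can be read.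

The next compound, compound 4 `CCCNC(=O)Nc1ccc(S(=O)(=O)Oc2ccccc2I)cc1`, differs from compound 2 by propylamino in place of isopropyl on a carbonyl carbon. Neither measured step touches this position in this way: the step from compound 1 to compound 3 changed the same chain by a single methyl and stayed within the scatter, and the step from compound 1 to compound 2 changed the other end of the molecule. Among the measured compounds shown here, no measured step therefore speaks directly to the exchange of isopropylcarbonyl for propylcarbamoyl. Given that both small changes so far left this assay unmoved, the step of a 1.1-fold higher number from compound 2 to compound 4 (0.03 log units; within the scatter) is expected to stay within the scatter. Compound 4 is estimated at 14000 nM, between 5000 nM and 40000 nM.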

Compound 4, half-maximal inhibitory concentration: 6800 nM
The estimate for compound 4 lay 2.1-fold (0.31 log units) above the measured number; the range from low to high includes it.
By their numbers in this assay, from the lowest: compounds 4, 2, 1 and 3 (each within the scatter of the next, the first and the last beyond it).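

In this assay the exchange of isopropylcarbonyl for propylcarbamoyl comes with a 1.9-fold lower number from compound 2 to compound 4 (0.28 log units; within the scatter) even though it is a different kind of change from the single methyl of the earlier step on this chain. Here the carbonyl carbon, whose other neighbour is an amide-type nitrogen, receives propylamino in place of isopropyl, which brings a nitrogen and one hydrogen-bond donor to this position, and the number still does not leave the scatter; in this iodo-bearing compound, then, the position accepts this exchange without a readable change in the assay. No evidence at hand accounts for this result or gives any property of the two groups as measured.

The compounds shown leave open whether a longer chain such as butylamino, or a chain ending in an amine or a carboxylic acid, would give a step beyond the scatter at this carbonyl carbon. They also leave open whether propylamino would give a similar step with isopropyl in place of the iodo group on the other end of the molecule.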